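A few compounds are considered here, and "the series" means these few. Any claim that something is new, unique, unknown or untested is made for them only; others in the source may bear on it.

Compound 3 `C/C(=N\Nc1nc(-c2ccccc2)cs1)c1sc(-c2ccccc2)nc1C` sits at the limit of the assay in a toxicity assay on THP-1 cells (Homo sapiens) for cytotoxicity, read by MTT assay; a higher number here means a weaker inhibitor of growth, a lower number a stronger inhibitor of growth: compound 3 gives > 100 ug/mL, a limit rather than a number. Compound 1 `C/C(=N\Nc1nc(-c2ccccc2)cs1)c1sc(C)nc1C` likewise gives > 100 ug/mL in this assay, a limit. Compound 2 `COc1ccc(-c2csc(N/N=C(\C)c3sc(C)nc3C)n2)cc1` gives > 100 ug/mL, again a limit. All three values share (the limit of > 100 ug/mL in this assay, at which 3 of the 3 values shown sit). The two measured steps, a step that the two limits leave unreadable from compound 1 to compound 2 and a step that the two limits leave unreadable from compound 1 to compound 3, therefore carry no readable size. Compound 4 `C/C(=N\Nc1nc(-c2ccc(Cl)cc2)cs1)c1sc(-c2ccccc2)nc1C` differs from compound 3 by chloro in place of hydrogen on an aromatic carbon. Going by the values given here, no measured step bears on a chloro substitution at this place, and the steps that exist give no size, so no step beyond the scatter is expected in this assay. The expected step is a step that the limit leaves unreadable from compound 3 to compound 4. Compound 4 is thus expected to remain near the limit, at 130 ug/mL with a range from 50 ug/mL to 400 ug/mL.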

Compound 4, concentration for 50% growth inhibition: > 100 ug/mL
Compound 4 gave a limit, no number (the forecaster's own chance of this, stated with the estimate: 75%); the middle value is on the limit's open side.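

No step can be read from compound 3 to compound 4, since both sit at a limit in this assay: the limit of > 100 ug/mL in this assay, at which 4 of the 4 values shown sit. The compounds shown leave open how any of these substitutions changes growth inhibition in this assay.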